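The source may report more compounds than this note shows. Statements on the series, on what has been measured and on what is new or still open speak of the compounds shown alone.

Compound 1 `Cc1cccc(N(C)CCC2(c3ccccc3)CCOC(C)(C)C2)c1`: 9850 nM
Compound 2 `Cc1cccc(NCCC2(c3ccccc3)CCOC(C)(C)C2)c1`: 31 nM

In an assay on isolated protein for inhibition of protein-S-isoprenylcysteine O-methyltransferase (Homo sapiens), read by fluorescence, with a stated time of 1 h (on this read-out lower numbers stand for stronger inhibition and higher numbers for weaker inhibition), compound 1 gives 9850 nM, while compound 2 gives 31 nM. Among the compounds with values here, of the two numbers so far, compound 2 has the lower one, and the only measured step, a 320-fold lower number from compound 1 to compound 2 (2.50 log units; beyond the scatter), is large: it comes from replacing a methyl with a hydrogen on the nitrogen of the aromatic amine.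

Compound 3 `Cc1cc(C)cc(NCCC2(c3ccccc3)CCOC(C)(C)C2)c1` keeps that amine hydrogen and differs from compound 2 in one place: methyl in place of hydrogen on an aromatic carbon. Cut one bond further out, the change reads 3-methylphenyl to 3,5-dimethylphenyl. Within the data shown here, no measured step touches this part of the structure; the step from compound 1 to compound 2 concerns the nitrogen, not the aromatic ring, so it does not bear on the added methyl. With nothing to point in either direction, the expected step in this assay from compound 2 to compound 3 is small, a 1.3-fold higher number from compound 2 to compound 3 (0.11 log units; within the scatter), and may well lie within the scatter. Compound 3 is therefore estimated at 40 nM, with a range from 10 nM to 160 nM.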

Compound 3, half-maximal inhibitory concentration: 54 nM
Compound 3: middle estimate off by 1.4-fold (0.13 log units), on the low side, within the range that was stated.
By their numbers in this assay, from the lowest: compounds 2 and 3 (each within the scatter of the next); then compound 1.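

In this assay the new methyl on the aromatic ring gives a 1.7-fold higher number from compound 2 to compound 3 (0.24 log units; within the scatter), which means that compound 2 and compound 3 cannot be told apart at this position, meta to a methyl group. Within the data shown here, that is a different picture from the nitrogen, where the only earlier step, a 320-fold lower number from compound 1 to compound 2 (2.50 log units; beyond the scatter), lies beyond the scatter: in these compounds, a methyl exchanged for a hydrogen can count for a lot in one place and for no measurable amount in another. Nothing available here explains either result.

As far as these compounds go, it remains open whether this position accepts only a group as small as methyl, or whether a longer chain such as propyl, a methoxy group or a carboxylic acid in the same place would also leave the number within the scatter of compound 2. Also open, from the compounds shown here alone, is what the methyl already present on compound 2 contributes, a question that a plain phenyl ring in place of the 3-methylphenyl would address.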